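Ester branching in a small dihydropyrimidine series

The source may report more compounds than this note shows. Statements on the series, on what has been measured and on what is new or still open speak of the compounds shown alone.

Measured compounds:
compound 1 `CC1=C(C(=O)OC(C)(C)C)C(c2cccs2)NC(=O)N1` — 26%
compound 2 `CCCOC(=O)C1=C(C)NC(=S)NC1c1ccco1` — 1%
compound 3 `CC1=C(C(=O)OCC(C)C)C(c2ccco2)NC(=S)N1` — 7%

In an assay on membranes from CHO cells for displacement of a labelled ligand from adenosine receptor A1 (Homo sapiens), read by scintillation counting, with a stated time of 60 min, tested at 1 uM (a lower number here means less inhibition, a higher number more inhibition at the concentration tested (going by the name of the read-out)), compound 3 gives 7%, the second highest of the three numbers. Its nearest neighbour is compound 2 with 1%, and the step of a number 6 percentage points higher from compound 2 to compound 3 (within the scatter) lies within the scatter. Compound 1 stands furthest away with 26%, beyond the scatter from compound 3; compound 1 and compound 3 differ in more than one place, so only the two values themselves can be compared.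

Compound 4 `CC1=C(C(=O)OC(C)(C)C)C(c2ccco2)NC(=S)N1` is not yet measured. It differs from compound 3 by tert-butyl in place of isobutyl on an oxygen next to a carbonyl group. Among the compounds with values here, the one measured step on the ester chain, a number 6 percentage points higher from compound 2 to compound 3 (within the scatter), moved the read-out within the scatter only, and no measured pair isolates isobutyl against tert-butyl. The expectation for the step of a number 5 percentage points higher from compound 3 to compound 4 (within the scatter) is therefore no movement beyond the scatter, with the higher number of compound 1 leaving room for a modest rise. Compound 4 is estimated at 12%, in the range 0% to 30%.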

Compound 4, a percentage reported as inhibition, at one concentration (the size of the read-out at that concentration, not a potency): 3%
Compound 4: the middle estimate sits 9 percentage points above what was measured; low and high end bracket the measured number.
By their numbers in this assay, from the lowest: compounds 2, 4 and 3 (each within the scatter of the next); then compound 1.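

The step of a number 4 percentage points lower from compound 3 to compound 4 (within the scatter) in this assay replaces isobutyl with tert-butyl on an oxygen next to a carbonyl group, and the step of a number 2 percentage points higher from compound 2 to compound 4 (within the scatter) replaces propyl with tert-butyl on the same oxygen. Propyl, isobutyl and tert-butyl therefore read alike within the scatter across compound 2, compound 3 and compound 4, so at this position neither form of branching separates from the straight chain. No measurement at hand bears on the reason for this flat reading.

Compound 1 gives 26% but differs from these compounds in more than one place. Within the data shown here, no measured pair isolates its ester, so that comparison stays open. Also open, as far as these compounds go, is whether a longer chain, a benzyl ester or an amide in place of the ester would read differently from these small alkyl groups.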